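A Longer Unsaturated Chain on a Weakly Active Core

This account rests on a few compounds, and the source may have more. Where it says the series, first, only, none or still open, it means among the compounds named here.

Of the compounds shown here, three built on one shared core have been tested in a functional assay on A549 cells (Homo sapiens) for antiproliferative activity, read by MTT assay, with a stated time of 72 h; a lower number here means a stronger inhibitor, a higher number a weaker inhibitor. Compound 1 `COc1ccc(Nc2nc3c(c(Oc4cccc(NC(=O)C=C(C)C)c4)n2)CSCC3)cc1` gives 26900 nM. Compound 2 `COc1ccc(Nc2nc3c(c(Oc4cccc(NC(=O)/C=C/C(C)C)c4)n2)CSCC3)cc1` gives 25900 nM. Compound 3 `COc1ccc(Nc2nc3c(c(Oc4cccc(NC(=O)C=C(C)C)c4)n2)CSCC3)cn1` gives 16800 nM. A fourth compound, compound 4 `COc1ccc(Nc2nc3c(c(Oc4cccc(NC(=O)/C=C/C(C)C)c4)n2)CSCC3)cn1`, has not yet been measured.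

Compound 2 differs from compound 1 in one place: 3-methylbut-1-en-1-yl in place of 2-methylprop-1-en-1-yl on a carbonyl carbon. That change made a 1.0-fold lower number from compound 1 to compound 2 (0.02 log units; within the scatter). Compound 3 differs from compound 1 elsewhere: 6-methoxypyridin-3-yl in place of 4-methoxyphenyl on a nitrogen on an aromatic ring. That change made a 1.6-fold lower number from compound 1 to compound 3 (0.20 log units; within the scatter). All three numbers sit close together, and no gap among them is beyond the scatter, so none of the three can be called more or less active than another.

Compound 4 stands to compound 3 exactly as compound 2 stands to compound 1. The difference is 3-methylbut-1-en-1-yl in place of 2-methylprop-1-en-1-yl on a carbonyl carbon, at the same place with the same neighbour, so it is the same change, now made on the core of compound 3 rather than the core of compound 1. With one earlier example that left the number essentially where it was, there is no reason to expect a different outcome here.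

For compound 4 the step expected is a 1.1-fold lower number from compound 3 to compound 4 (0.02 log units; within the scatter), because the same change earlier gave a 1.0-fold lower number from compound 1 to compound 2 (0.02 log units; within the scatter). Compound 4 is therefore estimated at 16000 nM in this assay. The number for compound 4 is expected to fall between 7000 nM and 40000 nM.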

Compound 4, half-maximal inhibitory concentration: 24200 nM
The estimate for compound 4 lay 1.5-fold (0.18 log units) below the measured number; measured number inside the range.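

The change in the chain, 3-methylbut-1-en-1-yl in place of 2-methylprop-1-en-1-yl on a carbonyl carbon, gave a 1.4-fold higher number from compound 3 to compound 4 (0.16 log units; within the scatter) in this assay, and this does not differ from what the same change gave on the other core: the same change on two cores in this assay, a 1.0-fold lower number (0.02 log units; within the scatter) from compound 1 to compound 2 and a 1.4-fold higher number (0.16 log units; within the scatter) from compound 3 to compound 4, 1.5-fold (0.17 log units) apart, within the scatter of two such steps

The change of 6-methoxypyridin-3-yl in place of 4-methoxyphenyl gave a 1.1-fold lower number from compound 2 to compound 4 (0.03 log units; within the scatter), and this too agrees with its earlier step: the same change on two cores in this assay, a 1.6-fold lower number (0.20 log units; within the scatter) from compound 1 to compound 3 and a 1.1-fold lower number (0.03 log units; within the scatter) from compound 2 to compound 4, 1.5-fold (0.17 log units) apart, within the scatter of two such steps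

So each change reads the same on both cores, but every one of these steps lies within the scatter, which means the agreement only shows that neither change produced a measurable shift on either core; it does not show that a change with a real, measurable effect would carry from one core to the other in the same way.

Still open, as far as these compounds go, is whether anything at these two places can move the number beyond the scatter. An amine or a carboxylic acid at the end of the chain on the carbonyl carbon, a much longer chain there, or a chlorine atom in place of the methoxy group on the aromatic ring could each test this, and the compounds shown give no hint of what they would do.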